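The compounds below may be only part of what the source reports. "The series", "measured", "known", "first", "only" and "open" are said of these compounds alone.

Measured in a functional assay on MIA PaCa-2 cells (Homo sapiens) for antiproliferative activity, read by sulforhodamine B assay, with a stated time of 48 h; on this read-out higher numbers stand for weaker inhibition and lower numbers for stronger inhibition:
- compound 1 `COc1cc(C(=O)/C=C\Nc2ccc(-c3nc4cc(OC)c(OC)c(OC)c4s3)cc2C)cc([N+](=O)[O-])c1OC`: 22000 nM
- compound 2 `COc1ccc(C(=O)/C=C\Nc2ccc(-c3nc4cc(OC)c(OC)c(OC)c4s3)cc2C)cc1F`: 1800 nM
- compound 3 `COc1cc(OC)c2sc(-c3ccc(N/C=C\C(=O)c4cc(OC)c(OC)c(OC)c4)c(C)c3)nc2c1`: 17000 nM

Among these three, compound 3 stands level with compound 1, the two numbers lying within the usual scatter of each other. Compound 2 gives a number clearly lower than that of compound 3, well beyond the scatter.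

The next compound to be tested is compound 4 `COc1cc(C(=O)/C=C\Nc2ccc(-c3nc4cc(OC)c(OC)c(OC)c4s3)cc2C)cc(OC)c1OC`. It differs from compound 3 in one place: methoxy in place of hydrogen on an aromatic carbon. Among the measured compounds shown here, no step between measured compounds isolates this change, so the expectation rests on indirect comparison. The core of compound 4 also occurs in compound 1, at 22000 nM, and in compound 2, at 1800 nM. The ketone-bearing ring of compound 4 is shared with compound 3, at 17000 nM. The first pair spans a wide range, so the core alone does not fix the number, while the shared ring points to the weak end. In this assay, no step beyond the scatter is therefore expected. The estimated step is a 1.4-fold lower number from compound 3 to compound 4 (0.15 log units; within the scatter), which would stay within the scatter. For compound 4 the estimated value is 12000 nM, with an expected range from 3000 nM to 40000 nM.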

Compound 4, half-maximal inhibitory concentration: 22800 nM
Beside the measured number, compound 4's estimate is 1.9-fold (0.28 log units) below it, within the range that was stated.
By their numbers in this assay, from the lowest: compound 2; then compounds 3, 1 and 4 (each within the scatter of the next).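

In this assay, among the compounds shown here, methoxy in place of hydrogen on an aromatic carbon that is ortho to two methoxy groups, meta to a fused ring and para to a fused ring gives a 1.3-fold higher number from compound 3 to compound 4 (0.13 log units; within the scatter), the first direct reading of this position, and here it takes a methoxy group without a step beyond the scatter. On the ketone-bearing ring, methoxy in place of nitro likewise stays within the scatter, with a 1.0-fold higher number from compound 1 to compound 4 (0.02 log units; within the scatter), whereas 3,4,5-trimethoxyphenyl in place of 3-fluoro-4-methoxyphenyl on a carbonyl carbon gives a 13-fold higher number from compound 2 to compound 4 (1.10 log units; beyond the scatter), so the large difference in this set now rests on a single change to that ring. Nothing in the data shown accounts for either outcome.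

At the position on the fused ring system, the compounds shown carry only hydrogen and methoxy, so what an amine, a hydroxyl group or a longer alkoxy chain would do there remains open. Going by these compounds, it also remains open whether methoxy in place of hydrogen at this position would stay within the scatter with the 3-fluoro-4-methoxyphenyl group on the carbonyl carbon.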